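Moving a Methyl on the Sulfonamide of Compound 1

A few compounds are considered here, and "the series" means these few. Any claim that something is new, unique, unknown or untested is made for them only; others in the source may bear on it.

Compound 1 `CN(c1ccccc1)S(=O)(=O)c1ccc(NC(=O)c2ccc(Cl)cc2Cl)cc1` gives 50% in a functional assay on HEK293 cells for agonist activity at probable G-protein coupled receptor 27 (Homo sapiens), read by a luciferase reporter and beta-arrestin recruitment, with a stated time of 10 min (a higher number here means a larger maximal response, a lower number a smaller maximal response), the lowest of the three values shown; compound 2 `O=C(Nc1ccc(S(=O)(=O)Nc2ccccc2)cc1)c1ccc(Br)cc1F` gives 67% and compound 3 `O=C(Nc1ccc(S(=O)(=O)Nc2ccccc2)cc1)c1ccc(Cl)nc1F` gives 78%. Going by the values given here, the only measured single-point step, a number 11 percentage points higher from compound 2 to compound 3 (beyond the scatter), changes the carbonyl side and not the sulfonamide, so it does not bear directly on the change leading to compound 4 `Cc1ccccc1NS(=O)(=O)c1ccc(NC(=O)c2ccc(Cl)cc2Cl)cc1`: (2-methylphenyl)amino in place of methyl(phenyl)amino on a sulfonyl sulfur. Among the compounds with values here, no measured step tests this change, so the expectation rests on compound 2 and compound 3, whose sulfonyl sulfur also carries an amino group with one hydrogen-bond donor and whose values stand higher than that of compound 1, although their carbonyl sides differ as well. Compound 4 is therefore expected to move modestly upward, a number 12 percentage points higher from compound 1 to compound 4 (beyond the scatter), to an estimated 62% with a range from 42% to 80%.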

Compound 4, largest response reached (Emax), in percent of the reference or control that the assay uses: 32%
For compound 4 the middle estimate is 30 percentage points above the measured one; the measured number lies below the stated range.
By their numbers in this assay, from the lowest: compound 4; then compound 1; then compound 2; then compound 3.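

In this assay, the change on the sulfonyl sulfur gives a number 18 percentage points lower from compound 1 to compound 4 (beyond the scatter), so with the carbonyl side held fixed, gaining the hydrogen-bond donor does not raise the response. The higher values of compound 2 and compound 3 therefore cannot be credited to that donor alone. Nothing available explains the drop.

This single step cannot separate gaining the nitrogen hydrogen from placing the methyl on the ring. From the compounds shown here alone, how a (2-methoxyphenyl)amino group on the sulfonyl sulfur would compare also remains open.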